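Trifluoromethylphenyl replaces methylpyrazolyl on a shared core

This account rests on a few compounds, and the source may have more. Where it says the series, first, only, none or still open, it means among the compounds named here.

Measured so far:
Compound 1 `Cc1nn(-c2nc(-c3ccc(Cl)c(Cl)c3)c(SC(C)C)s2)c(C(=O)O)c1-c1cc(C#N)cc(C(F)(F)F)c1`: 3600 nM
Compound 2 `COc1cc(C#N)cc(-c2c(C)nn(-c3nc(-c4ccc(Cl)c(Cl)c4)c(SC(C)C)s3)c2C(=O)O)c1`: 5200 nM
Compound 3 `Cc1nn(-c2nc(-c3ccc(Cl)c(Cl)c3)c(SC(C)C)s2)c(C(=O)O)c1-c1cnn(C)c1`: 6800 nM

All three were tested in a functional assay on BJAB cells (Homo sapiens) for antiproliferative activity, with a stated time of 4 days; on this read-out higher numbers stand for an effect only at larger amounts of compound and lower numbers for an effect already at smaller amounts. Compound 3 has the highest of the three numbers, but its nearest neighbour is compound 2, and even the distance to compound 1 stays within the scatter, so the three compounds cannot be told apart on these numbers.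

Compound 4 `Cc1nn(-c2nc(-c3ccc(Cl)c(Cl)c3)c(SC(C)C)s2)c(C(=O)O)c1-c1ccccc1C(F)(F)F` has not yet been measured. It differs from compound 3 in one place: 2-(trifluoromethyl)phenyl in place of 1-methyl-1H-pyrazol-4-yl on an aromatic carbon. The group entering is a carbon-only six-membered ring bearing a trifluoromethyl group, so the two steps that bear on it are those in which the pyrazolyl group arrived, a 1.9-fold higher number from compound 1 to compound 3 (0.28 log units; within the scatter) and a 1.3-fold higher number from compound 2 to compound 3 (0.12 log units; within the scatter). Both were small. On that basis, a change in the reverse direction, an aryl ring in place of the pyrazolyl group, is expected to give no step beyond the scatter in this assay, with at most a slight drift toward a lower number.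

The expected step is a 1.5-fold lower number from compound 3 to compound 4 (0.18 log units; within the scatter). For compound 4 the estimate in this assay is 4500 nM, with a range from 2000 nM to 10000 nM.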

Compound 4, half-maximal effective concentration: 5200 nM
For compound 4 the middle estimate is 1.2-fold (0.06 log units) below the measured one; measured number inside the range.
By their numbers in this assay, from the lowest: compounds 1, 2, 4 and 3 (each within the scatter of the next).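

This position on the shared core now holds a carbon-only aromatic ring with no nitrile without a step beyond the scatter in this assay: 2-(trifluoromethyl)phenyl in place of 1-methyl-1H-pyrazol-4-yl gives a 1.3-fold lower number from compound 3 to compound 4 (0.12 log units; within the scatter) even though the entering group has 10 heavy atoms against 6, and 0 hydrogen-bond acceptors against 2. Compound 1 and compound 2 each carry a nitrile on their phenyl ring and compound 4 carries none, yet no change at the digits printed from compound 2 to compound 4 (within the scatter) and a 1.4-fold higher number from compound 1 to compound 4 (0.16 log units; within the scatter) are what those swaps give. Among these four compounds, then, neither the nitrile nor the hydrogen-bond acceptors of the pyrazolyl group are needed for a number in this range.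

From the compounds shown here alone, since all four groups lie within the scatter of one another, it remains open whether any group at this position can move the number clearly, for instance one carrying an amine or a longer alkyl chain. Nothing available explains why such different groups give numbers so close together.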